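The source may report more compounds than this note shows. Statements on the series, on what has been measured and on what is new or still open speak of the compounds shown alone.

Measured compounds in an assay on cells for displacement of a labelled ligand from Neuronal acetylcholine receptor; alpha3/beta4 (Homo sapiens); a higher number here means a weaker inhibitor, a lower number a stronger inhibitor:
compound 1 `O=C(Nc1ccc(F)cc1F)c1cncc(N2CC3CC(C2)N3)c1` gives 50 nM
compound 2 `O=C(Nc1ccc(Cl)cc1)c1cncc(N2CC3CC(C2)N3)c1` gives 123 nM

Among the measured compounds shown here, compound 2 stands at the higher of the two numbers so far. For the measured compounds named here, its only neighbour is compound 1, and the single measured step between them, a 2.5-fold higher number from compound 1 to compound 2 (0.39 log units; beyond the scatter), is modest but lies beyond the scatter.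

Compound 3 `O=C(NCc1ccccc1)c1cncc(N2CC3CC(C2)N3)c1` is not yet measured. Its change from compound 2 is benzyl in place of 4-chlorophenyl on an amide-type nitrogen. Going by the values given here, the one measured step, a 2.5-fold higher number from compound 1 to compound 2 (0.39 log units; beyond the scatter), exchanges one aryl group for another on the same amide-type nitrogen; it does not exchange an aryl group for a benzyl group, so it bears on the present step only loosely, showing that alterations at this nitrogen move the number by a modest amount. Among the compounds with values here, no measured pair shows what a benzyl group does at this position. For compound 3 the expected step from compound 2 is therefore a modest rise in the number, a 2.4-fold higher number from compound 2 to compound 3 (0.39 log units; beyond the scatter), held with wide uncertainty. Compound 3 is estimated at 300 nM in this assay, with a range from 100 nM to 1000 nM.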

Compound 3, inhibition constant: 1600 nM
Estimate against measurement, compound 3: 5.3-fold (0.73 log units) below; the whole stated range lies below it.
By their numbers in this assay, from the lowest: compound 1; then compound 2; then compound 3.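

In this assay, replacing either aryl group with benzyl on the amide-type nitrogen costs far more than exchanging one aryl group for the other: the benzyl steps are a 13-fold higher number from compound 2 to compound 3 (1.11 log units; beyond the scatter) and a 32-fold higher number from compound 1 to compound 3 (1.51 log units; beyond the scatter), both large, against the modest 2.5-fold higher number from compound 1 to compound 2 (0.39 log units; beyond the scatter). This position therefore responds much more strongly to some changes than the first pair suggested, even though 4-chlorophenyl and benzyl have the same heavy-atom count and each has one six-membered aromatic ring of carbon only, so those counts do not separate the two groups. No measurement given here explains the size of these steps.

The change from 4-chlorophenyl to benzyl both removes the chlorine and inserts a carbon link to the ring, and the compounds shown do not separate these two changes, which a plain phenyl or a 4-chlorobenzyl group on this nitrogen would begin to do. Also open, going by these compounds, is how a longer chain, such as 2-phenylethyl, or a simple alkyl group such as cyclohexyl would read at this nitrogen.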